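Hydrazone series: whole-animal inhibition in rat, compound 4 outlook

The source may report more compounds than this note shows. Statements on the series, on what has been measured and on what is new or still open speak of the compounds shown alone.

Measured in a functional assay on the whole organism with Rattus norvegicus as the target; on this read-out lower numbers stand for an effect already at smaller amounts and higher numbers for an effect only at larger amounts of compound:
compound 1 `CC1CCC(=NNc2ccccc2)c2ncc(C(=O)NO)c(=O)n21`: > 100 umol/kg
compound 2 `CC1CCC(=NNc2ccccc2C(=O)O)c2ncc(C(=O)NO)c(=O)n21`: > 100 umol/kg
compound 3 `Cc1ccc(NN=C2CCC(C)n3c2ncc(C(=O)O)c3=O)cc1C`: > 100 umol/kg

Compound 3 gives only a limit of this assay, > 100 umol/kg, and so sits at the limit of > 100 umol/kg in this assay, at which 3 of the 3 values shown sit. For the measured compounds named here, the sole one-place step between measured compounds, a step that the two limits leave unreadable from compound 1 to compound 2, runs between two limits and its size cannot be read. Compound 4 `Cc1cccc(Cl)c1NN=C1CCC(C)n2c1ncc(C(=O)O)c2=O` differs from compound 3 by 2-chloro-6-methylphenyl in place of 3,4-dimethylphenyl on an amine nitrogen. Going by the values given here, no measured step bears on this change, and no compound of the set has yet given a number in this assay. For compound 4 a limit is again expected, so no step beyond the scatter is anticipated, a step that the limit leaves unreadable from compound 3 to compound 4 being the estimated shift. The estimate for compound 4 is 150 umol/kg, with a range from 50 umol/kg to 500 umol/kg.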

Compound 4, dose for 50% inhibition: > 100 umol/kg
Compound 4: a limit, no number; the forecaster's own chance of this, stated with the estimate: 80%; the middle value is on the limit's open side.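

For the compounds shown here, compound 4 gives only a limit, as does compound 3, and no step between compound 3 and compound 4 can be read. The compounds shown leave open what number, if any, 2-chloro-6-methylphenyl in place of 3,4-dimethylphenyl would give in this assay and whether any compound here gives a number at all.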